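Morpholine Amide to Dimethylamide on a Shared Core

The compounds below may be only part of what the source reports. "The series", "measured", "known", "first", "only" and "open" are said of these compounds alone.

Compound 2 `O=C(/C=C/c1ccncc1-c1ccc2ccccc2c1)N1CCOCC1` was tested in a functional assay on MCF7 cells (Homo sapiens) for inhibition, read by sulforhodamine B assay, with a stated time of 72 h; a higher number here means a weaker inhibitor of growth, a lower number a stronger inhibitor of growth. In this assay compound 2 gives > 10000 nM, which is a limit of the assay rather than a number. Compound 1 `NC(=O)/C=C/c1ccncc1-c1ccc2ccccc2c1` likewise gives only a limit in this assay, > 10000 nM. Among the compounds with values here, the single measured step, a step that the two limits leave unreadable from compound 1 to compound 2, therefore carries no readable size. Compound 3 `CN(C)C(=O)/C=C/c1ccncc1-c1ccc2ccccc2c1` differs from compound 2 in one place: dimethylamino in place of morpholin-4-yl on a carbonyl carbon. Within the data shown here, both known values sit at the limit of > 10000 nM in this assay, at which 2 of the 2 values shown sit, so no measured step speaks to the change. The expected step is a step that the limit leaves unreadable from compound 2 to compound 3. Compound 3 is estimated at 15000 nM, within a range of 5000 nM to 50000 nM.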

Compound 3, concentration for 50% growth inhibition: 8190 nM
Beside the measured number, compound 3's estimate is 1.8-fold (0.26 log units) above it; the measured number falls inside the stated range.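

Compound 3 is the only compound shown with a number rather than a limit in this assay, so a group on this carbonyl carbon can now be tied to a measured value. Dimethylamino in place of morpholin-4-yl gives an at least 1.2-fold lower number from compound 2 to compound 3 (0.08 log units; that floor lies within the scatter), and dimethylamino in place of amino gives an at least 1.2-fold lower number from compound 1 to compound 3 (0.08 log units; that floor lies within the scatter). Both steps are floors only, because the other two compounds sit at a limit: the limit of > 10000 nM in this assay, at which 2 of the 3 values shown sit.

Going by these compounds, how far compound 1 and compound 2 truly lie from compound 3 stays open. So does what methylamino or piperidin-1-yl would give on this carbonyl carbon.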